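The source may hold more compounds than are shown below. What is called first, only, known or untested is meant among the compounds shown, and "the series" means these compounds.

Of the compounds shown here, three built on one shared core have been tested in a functional assay on DLD-1 cells (Homo sapiens) for cytotoxicity, with a stated time of 48 h; a lower number here means a stronger inhibitor, a higher number a weaker inhibitor. Compound 1 `CC(C)C(=O)Oc1ccc2oc(/C=C/[S+](C)[O-])cc(=O)c2c1` gives 9100 nM. Compound 2 `C[S+]([O-])/C=C/c1cc(=O)c2cc(Cl)ccc2o1` gives 6500 nM, and compound 3 `CCCCC(=O)Oc1ccc2oc(/C=C/[S+](C)[O-])cc(=O)c2c1` gives 6700 nM. Among these three numbers compound 3 stands second highest, yet every gap to its neighbours lies within the scatter: a 1.4-fold lower number from compound 1 to compound 3 (0.13 log units; within the scatter) and a 1.0-fold higher number from compound 2 to compound 3 (0.01 log units; within the scatter). Compound 4 `CC(C)CC(=O)Oc1ccc2oc(/C=C/[S+](C)[O-])cc(=O)c2c1` differs from compound 3 at one spot: isopropyl in place of propyl on a saturated chain carbon bound to a carbonyl carbon. For the measured compounds named here, the one earlier change on this same chain, a 1.4-fold lower number from compound 1 to compound 3 (0.13 log units; within the scatter), stayed within the scatter, and even swapping chloro for (butylcarbonyl)oxy moved little, as a 1.0-fold higher number from compound 2 to compound 3 (0.01 log units; within the scatter) shows. Hence no step beyond the scatter is expected in this assay, no change at the digits printed from compound 3 to compound 4 (within the scatter). Compound 4 is expected to give about 6700 nM, between 3000 nM and 15000 nM.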

Compound 4, half-maximal inhibitory concentration: 6100 nM
Compound 4: the middle estimate sits 1.1-fold (0.04 log units) above what was measured, within the range that was stated.
By their numbers in this assay, from the lowest: compounds 4, 2, 3 and 1 (each within the scatter of the next).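

Swapping butyl for isobutyl on the carbonyl carbon uses the same atoms joined differently, and in this assay this rearrangement leaves the number within the scatter (a 1.1-fold lower number from compound 3 to compound 4 (0.04 log units; within the scatter)). The other two comparisons also stay within it, with isobutyl in place of isopropyl (a 1.5-fold lower number from compound 1 to compound 4 (0.17 log units; within the scatter)) and (isobutylcarbonyl)oxy in place of chloro (a 1.1-fold lower number from compound 2 to compound 4 (0.03 log units; within the scatter)), so branching this chain brings no detectable change among these compounds. No available evidence explains this flat result. As far as these compounds go, whether an amine, a carboxylic acid or a much longer chain in place of this group would move the number beyond the scatter remains open.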